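The compounds below may be only part of what the source reports. "The series", "measured", "known", "first", "only" and "open" are said of these compounds alone.

Working notes on the series. Compound 3 `C=C(c1ccc(OC)cc1NC(=O)CO)c1ccc(OC)c2c1C=CC(C)(C)O2` holds the lowest of the three numbers in a functional assay on HCT-8 cells (Homo sapiens) for antiproliferative activity, read by MTT assay, with a stated time of 48 h (a higher number here means a weaker inhibitor, a lower number a stronger inhibitor), at 470 nM. Compound 1 `CNCC(=O)Nc1cc(OC)ccc1C(=O)c1ccc(OC)c2c1C=CC(C)(C)O2` gives 3460 nM and compound 2 `CCNCC(=O)Nc1cc(OC)ccc1C(=O)c1ccc(OC)c2c1OC(C)(C)C=C2` gives 3690 nM. Each of these two lies above compound 3 by more than the scatter, while they lie within the scatter of each other.

The next compound to read is compound 4 `C=C(c1ccc(OC)cc1NC(=O)CN)c1ccc(OC)c2c1C=CC(C)(C)O2`. It differs from compound 3 in one place: amino in place of hydroxy on a saturated chain carbon bound to a carbonyl carbon. In words, this is amino in place of hydroxy on a saturated chain carbon bound to a carbonyl carbon, which can also be read as hydroxymethyl to aminomethyl.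

For the measured compounds named here, no measured pair shows this change alone. Compound 1 and compound 2 each differ from compound 3 in more than this one place, and their values do not isolate the swap. Going by the values given here, the only direct anchor is compound 3 at 470 nM. The step expected in this assay is a 1.3-fold higher number from compound 3 to compound 4 (0.11 log units; within the scatter), a small move toward a higher number that is not expected to go beyond the scatter. Among the compounds with values here, the uncertainty is wide in both directions, given that no measured step informs it. For compound 4 the estimated value is 600 nM, with an expected range of 180 nM to 2000 nM.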

Compound 4, half-maximal inhibitory concentration: 520 nM
For compound 4 the middle estimate is 1.2-fold (0.06 log units) above the measured one; the measured number falls inside the stated range.
By their numbers in this assay, from the lowest: compounds 3 and 4 (each within the scatter of the next); then compounds 1 and 2 (each within the scatter of the next).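

In this assay, for the compounds shown here, amino in place of hydroxy on a saturated chain carbon bound to a carbonyl carbon gives a 1.1-fold higher number from compound 3 to compound 4 (0.04 log units; within the scatter) and this is the first reading of the change on its own, which compounds 1 and 2 could not supply, as each differs from compound 3 in more than one place. At this position, with the shared core held constant, hydroxymethyl and aminomethyl cannot be told apart in this assay, and the counts of hydrogen-bond donors and acceptors also stay the same across the step. No measurement on hand accounts for this result or ties it to any property of either group.

The compounds shown leave open whether the same position accepts a group of another kind, such as a dimethylamino group, a carboxylic acid or a longer chain like 2-aminoethyl, without a step beyond the scatter. Going by these compounds alone, they also leave open which structural difference separates compound 3 and compound 4 from compound 1 and compound 2, as no pair here isolates the side chain from the rest of the structure.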